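Amide chain length on the shared core

The source may report more compounds than this note shows. Statements on the series, on what has been measured and on what is new or still open speak of the compounds shown alone.

For the measured compounds named here, compound 1 `CNC(=O)c1cc(Oc2ccc(NC(=O)c3cc4cccnc4n(-c4ccc(F)cc4)c3=O)cc2)ccn1` gives 110 nM in a functional assay on A549 cells (Homo sapiens) for antiproliferative activity, read by MTT assay, with a stated time of 72 h (on this read-out lower numbers stand for stronger inhibition and higher numbers for weaker inhibition), the lower of the two numbers measured so far. Compound 2 `CNC(=O)c1cc(Oc2ccc(NC(=O)c3cc4cccnc4n(-c4ccc(OC)cc4)c3=O)cc2)ccn1` gives 3110 nM, and the step of a 28-fold higher number from compound 1 to compound 2 (1.45 log units; beyond the scatter) is the only one measured; it changes a different group and carries no direct information about the amide substituent. Compound 3 `CCCNC(=O)c1cc(Oc2ccc(NC(=O)c3cc4cccnc4n(-c4ccc(F)cc4)c3=O)cc2)ccn1` differs from compound 1 by ethyl in place of hydrogen on a saturated chain carbon bound to an amide-type nitrogen. Going by the values given here, no measured step touches this part of the molecule. The estimated step of a 1.8-fold higher number from compound 1 to compound 3 (0.26 log units; within the scatter) is expected to be modest, toward a somewhat higher number. Compound 3 is therefore expected to give about 200 nM, with a range from 60 nM to 700 nM.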

Compound 3, half-maximal inhibitory concentration: 62 nM
Compound 3: middle estimate off by 3.2-fold (0.51 log units), on the high side; the range from low to high includes it.
By their numbers in this assay, from the lowest: compounds 3 and 1 (each within the scatter of the next); then compound 2.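

In this assay, methylcarbamoyl to propylcarbamoyl gives a 1.8-fold lower number from compound 1 to compound 3 (0.25 log units; within the scatter) and so leaves the number unchanged within the scatter. Ethyl in place of hydrogen at this saturated chain carbon is therefore tolerated on the core of compound 1, unlike the methoxy for fluoro change elsewhere in the molecule. No evidence on hand accounts for this result.

From the compounds shown here alone, it remains open whether a longer chain, a cyclopropyl group or a terminal amine on the amide nitrogen would hold the number in this range. Going by these compounds, whether propylcarbamoyl is equally tolerated alongside methoxy on the shared core also remains open.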